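Swapping the fluorophenyl of compound 2 for an ethylphenyl

This account rests on a few compounds, and the source may have more. Where it says the series, first, only, none or still open, it means among the compounds named here.

The two measured compounds share one core and differ only in the aryl group on the amide nitrogen. In an assay on membranes from Cerebral cortex for displacement of a labelled ligand from Neuronal acetylcholine receptor; alpha4/beta2 (Rattus norvegicus) (a lower number here means a stronger inhibitor, a higher number a weaker inhibitor), compound 1 `COc1cc(NC(=O)c2cncc(N3CC4CC(C3)N4)c2)cc(OC)c1` gives 0.985 nM, whereas compound 2 `O=C(Nc1ccc(F)cc1)c1cncc(N2CC3CC(C2)N3)c1` gives 0.01 nM. Compound 2 thus holds the lowest number of the two, and its gap to compound 1 lies beyond the scatter.

Compound 3 `CCc1cccc(NC(=O)c2cncc(N3CC4CC(C3)N4)c2)c1` has not yet been measured in this assay. Its difference from compound 2 is 3-ethylphenyl in place of 4-fluorophenyl on an amide-type nitrogen. Among the measured compounds shown here, no measured pair isolates this change, so nothing shows how this assay responds to it. Since only compound 2 reaches so low a number, the expectation is that compound 3 will sit somewhat weaker, and the step of a 15-fold higher number from compound 2 to compound 3 (1.18 log units; beyond the scatter) is the estimated size of that move. For compound 3 the estimate in this assay is 0.15 nM, within a range from 0.01 nM to 2 nM.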

Compound 3, inhibition constant: 1.3 nM
For compound 3 the middle estimate is 8.7-fold (0.94 log units) below the measured one; low and high end bracket the measured number.
By their numbers in this assay, from the lowest: compound 2; then compounds 1 and 3 (each within the scatter of the next).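

Among the compounds shown here, this is the first step measured at the aryl group on the amide-type nitrogen: in this assay the swap to 3-ethylphenyl from 4-fluorophenyl gives a 130-fold higher number from compound 2 to compound 3 (2.11 log units; beyond the scatter) and shows that the number at this position moves strongly with a single change of aryl group. Compound 2 now stands alone at the low end, while compound 1 and compound 3, which carry different aryl groups, lie within the scatter of each other. Nothing shown here gives a reason for the size of this step.

The compounds shown leave open whether the step follows from the ethyl group itself or from its place on the ring, a question that 4-ethylphenyl or 3-fluorophenyl would separate. As far as these compounds go, how an aryl group bearing an amine or a carboxylic acid would read in this assay also stays open.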